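Trading an aminophenyl for a dichlorophenyl on the ketone

This account rests on a few compounds, and the source may have more. Where it says the series, first, only, none or still open, it means among the compounds named here.

Measured compounds:
- compound 1, `COc1cc(-c2cc(/C=C/C(=O)c3ccc(N)cc3)[nH]n2)cc(OC)c1OC`: 470 nM
- compound 2, `COc1ccc(-c2cc(/C=C/C(=O)c3ccc(OC)c(OC)c3)[nH]n2)cc1`: 320 nM

Of the compounds shown here, two have been tested in a functional assay on RPMI-8226 cells (Homo sapiens) for inhibition, read by sulforhodamine B assay, with a stated time of 48 h; on this read-out lower numbers stand for stronger inhibition of growth and higher numbers for weaker inhibition of growth. Compound 1 gives 470 nM, the higher of the two numbers, while compound 2 gives 320 nM; the gap between compound 1 and compound 2 lies within the scatter, so the two show no real difference on this read-out.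

Compound 3, `COc1cc(-c2cc(/C=C/C(=O)c3ccc(Cl)c(Cl)c3)[nH]n2)cc(OC)c1OC`, keeps the core of compound 1 and differs from it in one place: 3,4-dichlorophenyl in place of 4-aminophenyl on a carbonyl carbon. Among the compounds with values here, no measured pair shows this kind of change, so nothing in the data sets its direction. The expected step from compound 1 to compound 3 in this assay is a 1.3-fold higher number from compound 1 to compound 3 (0.11 log units; within the scatter), which is taken to fall within the scatter. Compound 3 is therefore estimated at 600 nM, with a range from 150 nM to 2500 nM.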

Compound 3, concentration for 50% growth inhibition: 530 nM
For compound 3 the middle estimate is 1.1-fold (0.05 log units) above the measured one, and the stated range covers the measured number.
By their numbers in this assay, from the lowest: compounds 2, 1 and 3 (each within the scatter of the next).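

In this assay, within the data shown here, the swap on the carbonyl carbon gives the first single-place comparison in this set, a 1.1-fold higher number from compound 1 to compound 3 (0.05 log units; within the scatter) and so 3,4-dichlorophenyl and 4-aminophenyl cannot be told apart on this read-out. The leaving group carries 1 hydrogen-bond donor and 1 hydrogen-bond acceptor and the entering group carries 0 of each, yet on the core of compound 1 this exchange leaves the growth-inhibition number within the scatter. Nothing available explains this outcome.

On these data alone, this is a single pair on a single core, so it remains open whether the same exchange would behave alike on other cores. As far as these compounds go, it is also open whether a carboxylic acid or a longer alkyl chain on that carbonyl carbon would stay within the scatter of compound 1.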